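The source may hold more compounds than are shown below. What is called first, only, known or untested is meant among the compounds shown, and "the series" means these compounds.

Measured so far:
compound 1 `O=C(O)c1cccn1-c1ccc2c(c1)B(O)OC2`: > 10 ug/mL
compound 2 `O=C(c1ccc(F)cc1)c1ccn(-c2ccc3c(c2)B(O)OC3)c1`: > 10 ug/mL

Both readings come from an ADME assay on L929 cells (Mus musculus) for cytotoxicity, read by resazurin assay, with a stated time of 72 h; on this read-out higher numbers stand for weaker inhibition and lower numbers for stronger inhibition. The value of compound 1, > 10 ug/mL, is a limit of the assay and not a number. Compound 2 likewise gives only a limit, > 10 ug/mL. Compound 2 therefore stands at the limit of > 10 ug/mL in this assay, at which 2 of the 2 values shown sit, so no numerical order between the two compounds can be read from these data; they only share the same limit.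

Compound 3 `Cc1ccc(C(=O)c2ccn(-c3ccc4c(c3)B(O)OC4)c2)s1` differs from compound 2 in one place: 5-methylthiophen-2-yl in place of 4-fluorophenyl on a carbonyl carbon. Within the data shown here, no step between measured compounds is available to calibrate this change, so in this assay the expectation is a step of no size beyond the usual scatter, in no preferred direction. For compound 3 this means an expected step that the limit leaves unreadable from compound 2 to compound 3. Compound 3 is accordingly estimated at 15 ug/mL, in a range from 8 ug/mL to 40 ug/mL, and most likely reported once more only as a limit.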

Compound 3, half-maximal inhibitory concentration: > 10 ug/mL
Compound 3 was reported as a limit (the forecaster's own chance of this, stated with the estimate: 80%); the middle value lies beyond the limit too.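

Among these compounds, compound 3, like compound 2, is reported only as a limit, so no step between compound 2 and compound 3 can be read: the limit of > 10 ug/mL in this assay, at which 3 of the 3 values shown sit. The compounds shown leave open whether 5-methylthiophen-2-yl in place of 4-fluorophenyl on a carbonyl carbon changes the result in this assay at all.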